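Swapping chloro for amino on a fused purine-type core

The compounds below may be only part of what the source reports. "The series", "measured", "known", "first", "only" and "open" are said of these compounds alone.

Compound 1 `ClCc1cccc(Cn2cnc3c(Cl)nc(Cl)nc32)c1` stands at the top of the two numbers measured in a functional assay on OVCAR-4 cells (Homo sapiens) for cytotoxicity, read by sulforhodamine B assay, with a stated time of 48 h; on this read-out higher numbers stand for weaker inhibition of growth and lower numbers for stronger inhibition of growth: compound 1 gives 20000 nM, while compound 2 `ClCc1cccc(Cn2cnc3nc(Cl)nc(Cl)c32)c1` gives 2950 nM, a gap beyond the scatter. Compound 3 `Nc1nc(Cl)c2ncn(Cc3cccc(CCl)c3)c2n1` differs from compound 1 in one place: amino in place of chloro on an aromatic carbon. Within the data shown here, no measured pair tells how such a swap moves this assay, so any expectation rests on compound 1 alone. A step of a 1.3-fold lower number from compound 1 to compound 3 (0.12 log units; within the scatter) is expected, modest and toward stronger inhibition, not clearly beyond the scatter. Compound 3 is therefore estimated at 15000 nM, with a range from 4000 nM to 50000 nM.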

Compound 3, concentration for total growth inhibition: 4260 nM
For compound 3 the middle estimate is 3.5-fold (0.55 log units) above the measured one; the range from low to high includes it.
By their numbers in this assay, from the lowest: compounds 2 and 3 (each within the scatter of the next); then compound 1.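

In this assay, amino in place of chloro on an aromatic carbon between two ring nitrogen atoms gives a 4.7-fold lower number from compound 1 to compound 3 (0.67 log units; beyond the scatter), toward stronger inhibition of growth. Among these compounds, this is the first single-place change read at this position of the shared core, and it shows that the number responds to a change made there. Nothing measured here bears on why the number moves. From the compounds shown here alone, whether a methylamino or methoxy group on the same carbon would take the number further remains open.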